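Swapping the aromatic chloro for fluoro on compound 1

This account rests on a few compounds, and the source may have more. Where it says the series, first, only, none or still open, it means among the compounds named here.

Compound 1 `Cn1c(=O)[nH]c2c(cnn2-c2ccc(Cl)cc2)c1=N` stands second highest of the three numbers measured in an assay on membranes from brain for binding affinity to adenosine receptor A1 (Rattus norvegicus), read by radioligand binding, tested at 20 uM (on this read-out lower numbers stand for less inhibition and higher numbers for more inhibition at the one concentration tested (going by the name of the read-out)), where compound 1 gives 37%. Its nearest neighbour is compound 3 `Cn1c(=O)[nH]c2c(cnn2-c2ccc(Cl)cc2Cl)c1=N`, which gives 9%; the furthest is compound 2 `CCCn1c(=O)[nH]c2c(cnn2-c2cccc(Cl)c2)c1=N`, which gives 68%. Compound 2 differs from compound 1 in two places, so only the two values themselves can be compared. Among the measured compounds shown here, the one single-point step known, a number 28 percentage points lower from compound 1 to compound 3 (beyond the scatter), is a chloro in place of hydrogen on an aromatic carbon.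

The unmeasured compound 4 `Cn1c(=O)[nH]c2c(cnn2-c2ccc(F)cc2)c1=N` differs from compound 1 by fluoro in place of chloro on an aromatic carbon. For the measured compounds named here, no measured step exchanges one halogen for another, so the step from compound 1 to compound 3 bears on it only loosely, showing that a halogen on this ring can shift the number well beyond the scatter. Going by the values given here, with no direct precedent, compound 4 is expected to stay near compound 1, and the step of a number 7 percentage points lower from compound 1 to compound 4 (within the scatter) is estimated to be small. Compound 4 is therefore estimated at 30%, within a range of 10% to 55%.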

Compound 4, a percentage reported as inhibition, at one concentration (the size of the read-out at that concentration, not a potency): 26%
The estimate for compound 4 lay 4 percentage points above the measured number; the measured number falls inside the stated range.
By their numbers in this assay, from the lowest: compound 3; then compound 4; then compound 1; then compound 2.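

In this assay, fluoro in place of chloro on this aromatic carbon, para to a large group, gives a number 11 percentage points lower from compound 1 to compound 4 (beyond the scatter). The earlier single-point step only added a second chloro to the ring, whereas this one shows that the number also responds to which halogen sits at this place, even though the exchange leaves the heavy-atom, donor and acceptor counts unchanged. Nothing at hand bears on why the number moves with this exchange.

The compounds shown leave open how a bromo, a methoxy or an amine at this place would read. They also leave open whether the same exchange of chloro for fluoro would move the number similarly on a compound carrying a propyl chain in place of the methyl.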